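The source may report more compounds than this note shows. Statements on the series, on what has been measured and on what is new or still open speak of the compounds shown alone.

Compound 1 `C[C@H](NC(=O)Nc1cccc(C(F)(F)F)c1)c1ccccc1`: 93%
Compound 2 `C[C@H](NC(=O)Nc1cccc(F)c1)c1ccccc1`: 94%
Compound 3 `C[C@H](NC(=O)Nc1cccc(F)c1F)c1ccccc1`: 100%

All three were tested in an ADME assay on the whole organism with Oryza sativa as the target, tested at 1 uM; a higher number here means a weaker effect of the compound at the concentration tested, a lower number a stronger effect. Compound 3 gives the highest of the three numbers, but its nearest neighbour is compound 2, and the step of a number 6 percentage points higher from compound 2 to compound 3 (within the scatter) lies within the scatter, as does the gap to compound 1; none of the three compounds can therefore be set apart from the others.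

Compound 4 `C[C@H](NC(=O)Nc1cccc(C(F)(F)F)c1F)c1ccccc1` has not yet been measured. It differs from compound 3 in one place: trifluoromethyl in place of fluoro on an aromatic carbon. The change sits on the ring that carries the fluoro group, ortho to that fluoro group and meta to a large group.

Among the compounds with values here, two measured steps bear on this. The step of a number 1 percentage points higher from compound 1 to compound 2 (within the scatter) is the same exchange in the opposite direction, at the position that carries no fluoro neighbour, and it stayed within the scatter. The step of a number 6 percentage points higher from compound 2 to compound 3 (within the scatter) shows that adding the fluoro group itself also left this assay unchanged beyond the scatter. On that basis no step beyond the scatter is expected from compound 3 to compound 4, the estimated step being a number 4 percentage points lower from compound 3 to compound 4 (within the scatter). Compound 4 is therefore expected to give about 96%, within a range from 86% to 100%.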

Compound 4, a percentage reported as activity, at one concentration (the size of the read-out at that concentration, not a potency): 98%
Estimate against measurement, compound 4: 2 percentage points below; the range from low to high includes it.
By their numbers in this assay, from the lowest: compounds 1, 2, 4 and 3 (each within the scatter of the next).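

In this assay, trifluoromethyl in place of fluoro at this position, ortho to a fluoro group, gave a number 2 percentage points lower from compound 3 to compound 4 (within the scatter), so this change has now been seen with that fluoro group present as well as without it. The exchange between these two groups reads the same in both settings, and the fluoro group does not alter what the exchange does here: the same change on two cores in this assay, a number 1 percentage points higher (within the scatter) from compound 1 to compound 2 and a number 2 percentage points higher (within the scatter) from compound 4 to compound 3, 1 percentage points apart, within the scatter of two such steps Fluoro in place of hydrogen has also now been seen on a second core, with a number 5 percentage points higher from compound 1 to compound 4 (within the scatter), and it likewise reads the same whether the group beside it in the comparison is fluoro or trifluoromethyl: the same change on two cores in this assay, a number 6 percentage points higher (within the scatter) from compound 2 to compound 3 and a number 5 percentage points higher (within the scatter) from compound 1 to compound 4, 1 percentage points apart, within the scatter of two such steps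

All the compounds shown carry only fluoro or trifluoromethyl at this position, so what an amine, a methoxy group or a carboxylic acid there would do in this assay remains open. Within the data shown here, no step among them lies beyond the scatter, so it also remains open whether any change at this position, or elsewhere on the shared core, moves this read-out at all.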